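The compounds below may be only part of what the source reports. "The series", "measured", "known", "first", "only" and "open" are said of these compounds alone.

In a functional assay on HCT-116 cells (Homo sapiens) for inhibition, read by CCK-8 assay, with a stated time of 48 h (on this read-out lower numbers stand for stronger inhibition and higher numbers for weaker inhibition), compound 1 `COc1cc(-c2ccnc3cc(-c4c[nH]c5ccccc45)nn23)cc(OC)c1OC` gives 35 nM and compound 2 `COc1cc(-c2ccnc3cc(-c4ccc(C)cc4)nn23)cc(OC)c1OC` gives 48 nM in a pair that stays within the scatter, as a 1.4-fold higher number from compound 1 to compound 2 (0.14 log units; within the scatter) shows. Compound 3 `COc1cc(-c2ccnc3cc(-c4ccc(C)c(C)c4)nn23)cc(OC)c1OC` gives 261 nM as the highest number of the three, and a 7.5-fold higher number from compound 1 to compound 3 (0.87 log units; beyond the scatter) lies beyond the scatter. Compound 4 `COc1cc(-c2ccnc3cc(-c4ccccc4)nn23)cc(OC)c1OC` has not yet been measured. It carries phenyl in place of 3,4-dimethylphenyl on an aromatic carbon, with phenyl in place of 3,4-dimethylphenyl on an aromatic carbon as the counted difference. The step that bears most directly is a 5.4-fold higher number from compound 2 to compound 3 (0.74 log units; beyond the scatter) for methyl in place of hydrogen on an aromatic carbon, a modest rise beyond the scatter. Compound 4 carries neither methyl, and no unsubstituted phenyl has been measured, so a modest fall is expected, though its size is uncertain. The estimate therefore leans toward compound 2 at 48 nM rather than toward compound 3. The expected change is a 3.3-fold lower number from compound 3 to compound 4 (0.51 log units; beyond the scatter) in this estimate. For compound 4 the estimated value is 80 nM with an expected range from 30 nM to 220 nM in this assay.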

Compound 4, half-maximal inhibitory concentration: 3880 nM
Compound 4: the middle estimate sits 49-fold (1.69 log units) below what was measured; the measured number lies above the stated range.
By their numbers in this assay, from the lowest: compounds 1 and 2 (each within the scatter of the next); then compound 3; then compound 4.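

In this assay, the substituent on this aromatic carbon of the five-membered ring proves highly sensitive to methyl groups on the phenyl: an 81-fold higher number from compound 2 to compound 4 (1.91 log units; beyond the scatter) when hydrogen replaces the single methyl, and a 15-fold higher number from compound 3 to compound 4 (1.17 log units; beyond the scatter) when phenyl replaces 3,4-dimethylphenyl. The number therefore does not follow the methyl count in one direction, as the phenyl of compound 4 gives the highest value, the 3,4-dimethylphenyl of compound 3 an intermediate one and the 4-methylphenyl of compound 2 the lowest of these three. Phenyl also falls far short of 1H-indol-3-yl, with a 110-fold higher number from compound 1 to compound 4 (2.04 log units; beyond the scatter).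

As far as these compounds go, whether a chlorine atom, an amine or an ethyl chain on the phenyl would act as methyl does remains open. Nothing available explains the steep loss on removing the methyl.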